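The source may report more compounds than this note shows. Statements on the series, on what has been measured and on what is new or still open speak of the compounds shown alone.

Compound 1 `Cc1cccc(-n2cc(-c3ccc(/C=C4\C(=O)Nc5ccccc54)cc3)nn2)c1`: 4690 nM
Compound 2 `O=C1Nc2ccccc2/C1=C/c1ccc(-c2cn(-c3cccc(F)c3)nn2)cc1`: > 20000 nM

In a functional assay on MKN-45 cells (Homo sapiens) for inhibition, read by CCK-8 assay, with a stated time of 24 h (on this read-out lower numbers stand for stronger inhibition and higher numbers for weaker inhibition), compound 1 gives 4690 nM. For compound 2 the figure is > 20000 nM, a limit of the assay rather than a number; compound 2 sits at the limit of > 20000 nM in this assay, at which 1 of the 2 values shown sits. Among the measured compounds shown here, the one measured step, an at least 4.2-fold higher number from compound 1 to compound 2 (0.62 log units; beyond the scatter), is the only guide. Compound 3 `O=C1Nc2ccccc2/C1=C/c1ccc(-c2cn(-c3ccc(Cl)cc3)nn2)cc1` carries 4-chlorophenyl in place of 3-fluorophenyl on an aromatic nitrogen. For the measured compounds named here, no measured step shows this exact change, so the direction is open, and compound 3 is expected near or somewhat under the limit. Compound 3 is estimated at 15000 nM, within 4000 nM to 40000 nM. That estimate means an expected step of an at least 1.3-fold lower number from compound 2 to compound 3 (0.12 log units; that floor lies within the scatter).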

Compound 3, half-maximal inhibitory concentration: 16200 nM
Beside the measured number, compound 3's estimate is 1.1-fold (0.03 log units) below it, and the stated range covers the measured number.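

Compound 2 stands at a limit of the assay, not at a number: the limit of > 20000 nM in this assay, at which 1 of the 3 values shown sits. In this assay, 4-chlorophenyl on the aromatic nitrogen gives a measured number, but the change from 3-fluorophenyl shows an at least 1.2-fold lower number from compound 2 to compound 3 (0.09 log units; that floor lies within the scatter), so no real gain can be claimed. Against 3-methylphenyl, the same group shows a 3.5-fold higher number from compound 1 to compound 3 (0.54 log units; beyond the scatter), leaving compound 1 with the lowest number of the three.

From the compounds shown here alone, because 3-fluorophenyl and 4-chlorophenyl differ in both the halogen and its place on the ring, the contribution of each remains open. Going by these compounds, how an amine or a carboxylic acid on this phenyl ring would read also remains open.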